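Compound 1 to compound 4: one ring changes

The source may hold more compounds than are shown below. What is called first, only, known or untested is meant among the compounds shown, and "the series" means these compounds.

Measured in a functional assay on HOS cells (Homo sapiens) for inhibition, with a stated time of 72 h; a higher number here means a weaker inhibitor, a lower number a stronger inhibitor:
Compound 1 `NC1CCC(Nc2nc(NCc3ccc(-c4ccco4)cc3)c3ncn(C4CCCC4)c3n2)CC1`: 102 nM
Compound 2 `CC(C)(O)CNc1nc(NCc2ccc(-c3ccco3)cc2)c2ncn(C3CCCC3)c2n1`: 21400 nM
Compound 3 `NC1CCC(Nc2nc(NCc3ccc(-c4ccccc4)nc3)c3ncn(C4CCCC4)c3n2)CC1`: 206 nM

Of these three, compound 1 has the lowest number, 102 nM. Compound 4 `NC1CCC(Nc2nc(NCc3ccc(-c4ccco4)nc3)c3ncn(C4CCCC4)c3n2)CC1` departs from it in one place, on a saturated chain carbon bound to a nitrogen on an aromatic ring: 6-(furan-2-yl)pyridin-3-yl in place of 4-(furan-2-yl)phenyl on a saturated chain carbon bound to a nitrogen on an aromatic ring. The nearest guide is the modest 2.0-fold higher number from compound 1 to compound 3 (0.31 log units; beyond the scatter), which also brings in a pyridinyl group but loses the furan-2-yl. The large 210-fold higher number from compound 1 to compound 2 (2.32 log units; beyond the scatter) concerns the 4-aminocyclohexyl, which stays unchanged here, so it does not bear on this swap. A small rise in this assay is therefore expected, and the expected change is a 1.3-fold higher number from compound 1 to compound 4 (0.11 log units; within the scatter). Compound 4 is estimated at 130 nM, with an expected range of 55 nM to 320 nM.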

Compound 4, half-maximal inhibitory concentration: 44 nM
For compound 4 the middle estimate is 3.0-fold (0.47 log units) above the measured one; the whole stated range lies above it.
By their numbers in this assay, from the lowest: compound 4; then compound 1; then compound 3; then compound 2.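

In this assay the switch to 6-(furan-2-yl)pyridin-3-yl gives a 2.3-fold lower number from compound 1 to compound 4 (0.37 log units; beyond the scatter), so at this position the pyridinyl ring goes with a gain as long as the furan-2-yl stays. With that ring kept, furan-2-yl in place of phenyl gives a 4.7-fold lower number from compound 3 to compound 4 (0.67 log units; beyond the scatter), which shows that the outcome depends on the group the pyridinyl ring carries. Nothing available accounts for either step. As far as these compounds go, whether a thiophen-2-yl group in place of the furan-2-yl, or a pyrimidine ring in place of the pyridinyl ring, would hold this level remains open.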